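A few compounds are considered here, and "the series" means these few. Any claim that something is new, unique, unknown or untested is made for them only; others in the source may bear on it.

Measured compounds:
compound 1, `CNC(=O)CN1CC[C@H](n2c(Nc3ccccc3)nc3cnc(Nc4ccc(N5CCN(C)CC5)cc4)nc32)C1`: "not determined" (no result reported)
compound 2, `CN1CCN(c2ccc(Nc3ncc4nc(Nc5ccccc5)n([C@@H]5CCN(C(=O)OC(C)(C)C)C5)c4n3)cc2)CC1`: "not determined" (no result reported)
compound 3, `CN1CCN(c2ccc(Nc3ncc4nc(Nc5ccccc5)n([C@H]5CCN(S(=O)(=O)C6CC6)C5)c4n3)cc2)CC1`: 540 nM

Three compounds sharing one core have been looked at in a functional assay on A549 cells (Homo sapiens) for antiproliferative activity, read by MTT assay, with a stated time of 72 h; a higher number here means a weaker inhibitor, a lower number a stronger inhibitor. For compound 1 the result in this assay is "not determined" (no result reported), and for compound 2 it is likewise "not determined" (no result reported), so neither gives a number to compare with. Compound 3 is therefore the only compound with a number in this assay, where it gives 540 nM; on the numbers shown it stands alone, with nothing to rank it against.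

Compound 4, `CN1CCN(c2ccc(Nc3ncc4nc(Nc5ccccc5)n([C@@H]5CCN(S(=O)(=O)C6CC6)C5)c4n3)cc2)CC1`, has not yet been measured. It is the mirror-image partner of compound 3: the two compounds have the same atoms and bonds and differ only in configuration as drawn: 1 of 1 stereo elements differ; a stereocentre at a saturated ring carbon is drawn S in compound 3 and R in compound 4

Going by the values given here, no step between two measured compounds is available, so there is no footing for the size or direction of this change. Such a change can leave the potency about where it is or shift it either way, well beyond the scatter. As an estimate, compound 4 is expected to give 1000 nM in this assay, with a range from 200 nM to 6000 nM, which amounts to an expected step of a 1.9-fold higher number from compound 3 to compound 4 (0.27 log units; within the scatter).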

Compound 4, half-maximal inhibitory concentration: 2910 nM
Estimate against measurement, compound 4: 2.9-fold (0.46 log units) below; measured number inside the range.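

Mirror-image geometry at this one stereocentre matters in this assay: there is a 5.4-fold higher number from compound 3 to compound 4 (0.73 log units; beyond the scatter), so the S form drawn in compound 3 is the stronger of this pair. Until now, no pair of measured compounds had shown what any change at this position does, and this pair shows that the drawn configuration at the saturated ring carbon can by itself move the result. The gap belongs to that stereocentre alone, because nothing else separates the two structures: the fact that compounds 3 and 4 differ only in the configuration as drawn

On these data alone, whether the S form keeps its advantage with another group in place of the cyclopropylsulfonyl group, such as an acetyl group or a free amine, remains open, since compound 1 and compound 2 give no number for comparison. A single mirror-image pair also cannot show why the two forms differ in these cells.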